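The compounds below may be only part of what the source reports. "The series", "measured", "known", "first", "only" and "open" are said of these compounds alone.

Three related compounds have been tested in an in vitro ADME assay on microsomes (Mus musculus) for metabolic stability; a lower number here means that the compound disappears faster, a higher number that the compound lasts longer. Compound 1 `Cc1c2c(n3c1CCN(C(=O)[C@H](C)N)CC[C@H](C)Nc1cc-3ccc1C(N)=O)CC(C)(C)CC2=O` gives > 0.5 h, which is a limit of the assay and not a number. Compound 2 `Cc1c2c(n3c1CCN(C(=O)[C@@H](N)C(C)C)C[C@@H](C)[C@H](C)Nc1cc-3ccc1C(N)=O)CC(C)(C)CC2=O` gives 0.133 h, and compound 3 `Cc1c2c(n3c1CCN(C(=O)C(C)(C)N)C[C@@H](C)[C@H](C)Nc1cc-3ccc1C(N)=O)CC(C)(C)CC2=O` gives 0.367 h, the higher of the two actual numbers.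

The next structure, compound 4 `Cc1c2c(n3c1CCN(C(=O)[C@H](C)O)C[C@@H](C)[C@H](C)Nc1cc-3ccc1C(N)=O)CC(C)(C)CC2=O`, carries 1-hydroxyethyl in place of 1-amino-1-methylethyl on a carbonyl carbon, the same kind of place that changed between compound 2 and compound 3: 1-hydroxyethyl in place of 1-amino-1-methylethyl on a carbonyl carbon.

Among the measured compounds shown here, only one measured step bears on this change. Putting 1-amino-1-methylethyl in place of 1-amino-2-methylpropyl gave a 2.8-fold higher number from compound 2 to compound 3 (0.44 log units; beyond the scatter), a modest move. That step does not involve 1-hydroxyethyl, so it shows how much this place can matter in this assay but not which way the new change should go.

With no direction to go on, the best starting point is compound 3 at 0.367 h, with a shift of about that modest size possible either way. The expected change is small, a 1.0-fold lower number from compound 3 to compound 4 (0.02 log units; within the scatter), and no step beyond the scatter is predicted. For compound 4 the estimated half-life is 0.35 h, with an expected range from 0.15 h to 0.75 h.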

Compound 4, half-life: > 0.5 h
Compound 4: a limit, no number; the forecaster's own chance of this, stated with the estimate: 25%; at least 1.4-fold (0.15 log units) between middle value and limit.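

In this assay compound 4 stands at a limit of the assay and not at a number: the limit of > 0.5 h in this assay, at which 2 of the 4 values shown sit.

Among the compounds shown here, replacing 1-amino-1-methylethyl with 1-hydroxyethyl on this carbonyl carbon gives an at least 1.3-fold higher number from compound 3 to compound 4 (0.13 log units; that floor lies within the scatter), which points upward for the first time for this change, but that floor alone does not establish a real gain over compound 3. The firmer reading comes from the wider comparison, which gives an at least 3.7-fold higher number from compound 2 to compound 4 (0.57 log units; beyond the scatter) and shows that among these compounds a group carrying a hydroxyl instead of an amino group can reach a longer half-life than the 1-amino-2-methylpropyl group at this place.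

On these data alone, how far compound 4 really lies past the limit stays unknown, and so does the full size of both steps, which are floors and not exact differences. Also open, as far as these compounds go, is whether the result belongs to the hydroxyl group specifically, a question that the mirror-image form of 1-hydroxyethyl, a plain ethyl group, a methoxy-bearing chain or a carboxylic acid on the same carbonyl carbon could help to answer.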